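Swapping the Amine on a Deubiquitinase Inhibitor Series

The compounds below may be only part of what the source reports. "The series", "measured", "known", "first", "only" and "open" are said of these compounds alone.

Compound 1 `CC(C)NCc1ccc(-c2c3ncn(CC4(O)CCN(Cc5ccc(-c6ccco6)cc5Cl)CC4)c(=O)c3nn2C)cc1`: 29.1 nM
Compound 2 `Cn1nc2c(=O)n(CC3(O)CCN(Cc4ccc(-c5ccc[nH]5)cc4Cl)CC3)cnc2c1-c1ccc(CN)cc1`: 193 nM

In an assay on isolated protein for inhibition of ubiquitin carboxyl-terminal hydrolase 7 (Homo sapiens), with stated times of 30 min and 2 h (a higher number here means a weaker inhibitor, a lower number a stronger inhibitor), compound 1 gives 29.1 nM, the lowest of the two numbers measured. Compound 2 differs from it in more than one place and gives 193 nM, a higher number than compound 1, beyond the scatter.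

Compound 3 `CN(C)Cc1ccc(-c2c3ncn(CC4(O)CCN(Cc5ccc(-c6ccco6)cc5Cl)CC4)c(=O)c3nn2C)cc1` is not yet measured. It differs from compound 1 by dimethylamino in place of isopropylamino on a saturated chain carbon bound to an aromatic carbon, a small change in which the donor is lost but a single acceptor remains.

For the measured compounds named here, with no measured pair separated only by such a change, the step of a 1.3-fold higher number from compound 1 to compound 3 (0.12 log units; within the scatter) is expected to be no larger than the scatter, in either direction. Compound 3 is therefore estimated at 38 nM, with a range from 13 nM to 110 nM.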

Compound 3, half-maximal inhibitory concentration: 131 nM
Compound 3: the middle estimate sits 3.4-fold (0.54 log units) below what was measured; measured number outside the range, above it.
By their numbers in this assay, from the lowest: compound 1; then compounds 3 and 2 (each within the scatter of the next).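

In this assay, this first pair differing in one place shows that the amine on a saturated chain carbon bound to an aromatic carbon matters: dimethylamino in place of isopropylamino gives a 4.5-fold higher number from compound 1 to compound 3 (0.65 log units; beyond the scatter) with the rest of the molecule unchanged. The change also loses the hydrogen-bond donor, but this single pair cannot separate that loss from the change in the groups on the nitrogen. No measurement available here explains the step.

As far as these compounds go, whether methylamino or tert-butylamino at this place would keep the number near that of compound 1 remains open.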